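The source may hold more compounds than are shown below. What is called first, only, known or untested is meant among the compounds shown, and "the series" means these compounds.

The measured compounds are these. Compound 1 `CC/C=C/C(=O)Nc1cccc(Oc2nc(Nc3ccn(C)n3)nc3c2CSCC3)c1` in a functional assay on MCF7 cells (Homo sapiens) for antiproliferative activity, read by MTT assay, with a stated time of 72 h (on this read-out lower numbers stand for stronger inhibition and higher numbers for weaker inhibition), gives only a limit, > 50000 nM. Compound 2 `CCC/C=C/C(=O)Nc1cccc(Oc2nc(Nc3ccn(C)n3)nc3c2CSCC3)c1` in this assay gives 22600 nM. Compound 3 `CC/C=C/C(=O)Nc1cccc(Oc2nc(Nc3cccc(OC)c3)nc3c2CSCC3)c1` in this assay gives 24200 nM.

Compound 4 `CCC/C=C/C(=O)Nc1cccc(Oc2nc(Nc3cccc(OC)c3)nc3c2CSCC3)c1` has not yet been measured in this assay. It differs from compound 3 by methyl in place of hydrogen on a saturated chain carbon, two bonds along the chain from a double-bonded chain carbon. The same change is made from compound 1 to compound 2, where it is methyl in place of hydrogen on a saturated chain carbon, two bonds along the chain from a double-bonded chain carbon and brings an at least 2.2-fold lower number from compound 1 to compound 2 (0.34 log units; beyond the scatter); the size of that step is only a lower bound because of the limit of > 50000 nM in this assay, at which 1 of the 3 values shown sits. The two cores differ as 3-methoxyphenyl in place of 1-methyl-1H-pyrazol-3-yl on a nitrogen on an aromatic ring, a change that brings an at least 2.0-fold lower number from compound 1 to compound 3 (0.31 log units; beyond the scatter). The values of compound 2 and compound 3 lie within the scatter of one another.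

For compound 4 the step from compound 3 is expected to be a 2.4-fold lower number from compound 3 to compound 4 (0.38 log units; beyond the scatter), resting on the step of an at least 2.2-fold lower number from compound 1 to compound 2 (0.34 log units; beyond the scatter) seen for the same change, with the caution that the earlier step is only bounded from below. Compound 4 is therefore estimated at 10000 nM, within 4000 nM to 25000 nM.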

Compound 4, half-maximal inhibitory concentration: 32000 nM
Compound 4: middle estimate off by 3.2-fold (0.51 log units), on the low side; the measured number lies above the stated range.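

In this assay, the methyl that turns but-1-en-1-yl into pent-1-en-1-yl does not carry over from the core of compound 1 to the core of compound 3, where it gives a 1.3-fold higher number from compound 3 to compound 4 (0.12 log units; within the scatter), and the two steps differ: the same change on two cores in this assay, an at least 2.2-fold lower number (0.34 log units; beyond the scatter) from compound 1 to compound 2 and a 1.3-fold higher number (0.12 log units; within the scatter) from compound 3 to compound 4, at least 2.9-fold (0.46 log units) apart, beyond the scatter of two such steps. Read from the other side, the exchange of 1-methyl-1H-pyrazol-3-yl for 3-methoxyphenyl on the pent-1-en-1-yl compounds gives a 1.4-fold higher number from compound 2 to compound 4 (0.15 log units; within the scatter), so that change does not carry over either: the same change on two cores in this assay, an at least 2.0-fold lower number (0.31 log units; beyond the scatter) from compound 1 to compound 3 and a 1.4-fold higher number (0.15 log units; within the scatter) from compound 2 to compound 4, at least 2.9-fold (0.46 log units) apart, beyond the scatter of two such steps. Compound 1 gives only a limit, > 50000 nM, so the size of each gap is known from one side only, and a single pair of cores yields no general rule for the series: the limit of > 50000 nM in this assay, at which 1 of the 4 values shown sits.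

The compounds shown leave open how a longer chain, such as hex-1-en-1-yl, would behave on either core. They also leave open whether a plain phenyl or a pyridine ring on the nitrogen would follow the 3-methoxyphenyl compounds or the 1-methyl-1H-pyrazol-3-yl compounds.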